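Hydroxy for fluoro on the methoxyphenyl arm

The source may report more compounds than this note shows. Statements on the series, on what has been measured and on what is new or still open speak of the compounds shown alone.

Three compounds share the trimethoxyphenyl group and carry a substituted methoxyphenyl arm. Among the measured compounds shown here, compound 1 `COc1ccc(-c2nc3cnccc3n2-c2cc(OC)c(OC)c(OC)c2)cc1O` rests on a different core; in a functional assay on A549 cells (Homo sapiens) for antiproliferative activity, read by MTT assay, with a stated time of 48 h (on this read-out higher numbers stand for weaker inhibition and lower numbers for stronger inhibition), compound 1 gives only a limit, > 20000 nM, and this limit of > 20000 nM in this assay, at which 1 of the 3 values shown sits, is the one value that is not a number. On the shared core of the other two, compound 2 `COc1ccc(-c2cc3c(cn2)[nH]c(=O)n3-c2cc(OC)c(OC)c(OC)c2)cc1` gives 1120 nM in this assay, and compound 3 `COc1ccc(-c2cc3c(cn2)[nH]c(=O)n3-c2cc(OC)c(OC)c(OC)c2)cc1F` gives 2020 nM. For the measured compounds named here, the only single step measured, a 1.8-fold higher number from compound 2 to compound 3 (0.26 log units; within the scatter), shows that fluoro in place of hydrogen on the aromatic carbon left the number within the scatter; compound 3 thus stands beside compound 2 with no separation that the scatter allows one to call real.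

Compound 4 `COc1ccc(-c2cc3c(cn2)[nH]c(=O)n3-c2cc(OC)c(OC)c(OC)c2)cc1O` differs from compound 3 as follows: hydroxy in place of fluoro on an aromatic carbon. Going by the values given here, no measured step on this core touches a hydroxy group, and compound 1 carries its hydroxy on another core, so its limit does not read across. Among the compounds with values here, with the one measured step within the scatter and no evidence that the hydroxy group moves the number, compound 4 is expected to stay near compound 3, a step of a 1.3-fold lower number from compound 3 to compound 4 (0.10 log units; within the scatter). Compound 4 is therefore estimated at 1600 nM, between 400 nM and 6500 nM.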

Compound 4, half-maximal inhibitory concentration: 630 nM
Estimate against measurement, compound 4: 2.5-fold (0.40 log units) above, within the range that was stated.
By their numbers in this assay, from the lowest: compounds 4, 2 and 3 (each within the scatter of the next, the first and the last beyond it). At a limit, above all of these: compound 1.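

In this assay, among the compounds shown here, fluoro and hydroxy on this aromatic carbon, ortho to a methoxy group, give the first step on the shared core that lies beyond the scatter, namely a 3.2-fold lower number from compound 3 to compound 4 (0.51 log units; beyond the scatter), so the group at this position can move the number, if only modestly. The separation holds only between these two groups, since a 1.8-fold lower number from compound 2 to compound 4 (0.25 log units; within the scatter) leaves the hydroxy compound within the scatter of the compound with hydrogen at this place, just as a 1.8-fold higher number from compound 2 to compound 3 (0.26 log units; within the scatter) does for the fluoro compound, and neither group can be said to differ from hydrogen. Nothing shown here bears on what lies behind the step from fluoro to hydroxy.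

On these data alone, it stays open whether an amine, a carboxylic acid or a methoxy group on this same carbon would fall with the hydroxy compound or with the fluoro compound, and whether a longer chain such as ethoxy would be tolerated there. As far as these compounds go, compound 1, which also carries a hydroxy group, stands on a different core and gives only a limit, so how far the 3-hydroxy-4-methoxyphenyl arm depends on the shared core also remains open.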